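Adding a Second Bromine to a Hydroxyphenyl Amide

A few compounds are considered here, and "the series" means these few. Any claim that something is new, unique, unknown or untested is made for them only; others in the source may bear on it.

Compound 1 `COc1c(Br)cc(Br)cc1C(=O)Nc1ccc(Sc2nc3ccccc3s2)c(Cl)c1` in an assay for inhibition of HSP60/HSP10 (Homo sapiens), with a stated time of 60 min (on this read-out lower numbers stand for stronger inhibition and higher numbers for weaker inhibition), gives > 100000 nM, which is a limit of the assay and not a number.
Compound 2 `O=C(Nc1ccc(Sc2nc3ccccc3s2)cc1)c1cccc(Br)c1O` gives 26000 nM in this assay.
Compound 3 `COc1c(Br)cccc1C(=O)Nc1ccc(Sc2nc3ccccc3s2)c(Cl)c1` gives > 100000 nM in this assay, again a limit of the assay and not a number.

Within the data shown here, compound 2 thus carries the only number in the set; the other two values sit at the limit of > 100000 nM in this assay, at which 2 of the 3 values shown sit. The difference between the core of compound 2 and the core of compound 3 is not broken down here. From compound 3 to compound 1 the change is bromo in place of hydrogen on an aromatic carbon, and the step it made is a step that the two limits leave unreadable from compound 3 to compound 1.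

Compound 4 `O=C(Nc1ccc(Sc2nc3ccccc3s2)cc1)c1cc(Br)cc(Br)c1O` has not yet been measured. It differs from compound 2 by bromo in place of hydrogen on an aromatic carbon. Among the measured compounds shown here, this is the same kind of change as the one from compound 3 to compound 1, not the same: in compound 4 the entering bromo sits para to a hydroxy group, whereas in compound 1 it sits para to a methoxy group. The size of the measured step from compound 3 to compound 1 cannot be read. The expectation therefore rests on compound 2 alone and its 26000 nM. The step from compound 2 to compound 4 is expected to be a 1.3-fold lower number from compound 2 to compound 4 (0.11 log units; within the scatter). Compound 4 is therefore estimated at 20000 nM, most likely between 6000 nM and 70000 nM.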

Compound 4, half-maximal inhibitory concentration: 4700 nM
The estimate for compound 4 lay 4.3-fold (0.63 log units) above the measured number; measured number outside the range, below it.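

In this assay, the change from 3-bromo-2-hydroxyphenyl to 3,5-dibromo-2-hydroxyphenyl gives a 5.5-fold lower number from compound 2 to compound 4 (0.74 log units; beyond the scatter), so on this core the added bromo goes with stronger inhibition. The same kind of change from compound 3 to compound 1 cannot be sized, because both compounds sit at a limit of the assay and not at a number: the limit of > 100000 nM in this assay, at which 2 of the 4 values shown sit.

Among these compounds, the series therefore offers a single readable case of this change, and it does not show whether the gain carries over to another core, such as the one shared by compound 1 and compound 3, which carries a methoxy group where compound 4 has its hydroxy group.

The compounds shown leave open whether iodo or a nitrile entering at the same place on the core of compound 2 would shift the number as bromo does. They also leave open whether the step depends on the hydroxy group, a question that a pair differing only in hydroxy against methoxy on one core could address.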